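The compounds below may be only part of what the source reports. "The series", "measured", "known", "first", "only" and "open" are said of these compounds alone.

Among the measured compounds shown here, in an ADME assay on the whole organism (Rattus norvegicus, strain Sprague-Dawley) for pharmacokinetics, read by LC-MS, with a stated time of 30 min (on this read-out higher numbers stand for wider distribution into tissues and lower numbers for narrower distribution), compound 1 (`N#Cc1ccc(O[C@H]2CN(S(=O)(=O)c3ccc(Cl)cc3Cl)C[C@@]2(O)CO)cc1F`) gives 3.2 L/kg and compound 2 (`N#Cc1ccc(O[C@H]2CN(S(=O)(=O)c3ccc(Cl)cn3)C[C@@]2(O)CO)cc1F`) gives 2.2 L/kg as the only numbers so far, and the two lie within the scatter of each other. Compound 3 (`N#Cc1ccc(O[C@H]2CN(S(=O)(=O)c3ccc(C(F)(F)F)nc3)C[C@@]2(O)CO)cc1F`) differs from compound 1 only in the group on the sulfonyl sulfur (6-(trifluoromethyl)pyridin-3-yl in place of 2,4-dichlorophenyl on a sulfonyl sulfur), with 6-(trifluoromethyl)pyridin-3-yl in place of 2,4-dichlorophenyl. For the measured compounds named here, the one measured step bearing on this (a 1.5-fold lower number from compound 1 to compound 2 (0.16 log units; within the scatter)) has 5-chloropyridin-2-yl in place of 2,4-dichlorophenyl on the same sulfonyl sulfur, so no step beyond the scatter is expected in this assay for compound 3. Going by the values given here, no measured compound carries trifluoromethyl, so the range stays wide. The estimated step is a 1.3-fold lower number from compound 1 to compound 3 (0.12 log units; within the scatter) and remains an expectation only. The estimated value for compound 3 is 2.4 L/kg (expected range 1.2 L/kg to 4.6 L/kg).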

Compound 3, volume of distribution at steady state: 4.1 L/kg
For compound 3 the middle estimate is 1.7-fold (0.23 log units) below the measured one, and the stated range covers the measured number.
By their numbers in this assay, from the lowest: compounds 2, 1 and 3 (each within the scatter of the next).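

In this assay, the sulfonyl sulfur now carries a third group, 6-(trifluoromethyl)pyridin-3-yl, and a 1.3-fold higher number from compound 1 to compound 3 (0.11 log units; within the scatter) shows that this change from 2,4-dichlorophenyl leaves the number within the scatter. Among the compounds shown here, the step between the two pyridinyl groups, a 1.9-fold higher number from compound 2 to compound 3 (0.27 log units; within the scatter), is also within the scatter, so no step among the three compounds can be read as a real difference, with or without a hetero atom in the ring and with either chlorine or trifluoromethyl on it. Nothing available on these compounds offers a reason for these numbers.

On these data alone, whether an amine or a carboxylic acid on the ring at this position would give a step beyond the scatter remains open. The compounds shown also say nothing about changes to the shared core or its nitrile-bearing ring.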